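Hydrogen in place of methoxy on compound 2

A few compounds are considered here, and "the series" means these few. Any claim that something is new, unique, unknown or untested is made for them only; others in the source may bear on it.

In a functional assay on CCRF-CEM cells (Homo sapiens) for antiproliferative activity, read by sulforhodamine B assay, with a stated time of 48 h (on this read-out lower numbers stand for stronger inhibition and higher numbers for weaker inhibition), compound 1 (`O=C1NCCN1c1ccc(S(=O)(=O)Nc2cccc(Br)c2)cc1`) gives 110 nM and compound 2 (`COc1cc(NS(=O)(=O)c2ccc(N3CCNC3=O)cc2)cc(OC)c1`) gives 170 nM as a pair of values lying within the usual scatter of each other. Among the compounds with values here, compound 2 therefore stands level with the only other number available. Within the data shown here, compound 3 (`COc1cccc(NS(=O)(=O)c2ccc(N3CCNC3=O)cc2)c1`) has hydrogen in place of methoxy on an aromatic carbon as its one change from compound 2. Among the measured compounds shown here, no measured pair shows this change, so the data give no direct guide to its size or direction. Only a small move toward a higher number is expected, with no step beyond the scatter. The estimated step is a 1.3-fold higher number from compound 2 to compound 3 (0.11 log units; within the scatter) and would leave the two compounds level. The expected value for compound 3 is 220 nM in this assay with an estimated range of 80 nM to 600 nM on this read-out.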

Compound 3, half-maximal inhibitory concentration: 260 nM
Estimate against measurement, compound 3: 1.2-fold (0.07 log units) below, and the stated range covers the measured number.
By their numbers in this assay, from the lowest: compounds 1, 2 and 3 (each within the scatter of the next, the first and the last beyond it).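

Hydrogen in place of methoxy on this aromatic carbon gives a 1.5-fold higher number from compound 2 to compound 3 (0.18 log units; within the scatter) in this assay, so compound 2 and compound 3 stand level and this methoxy group can be lost without a step beyond the scatter. Within the data shown here, the other comparison is the first to pass the scatter: methoxy in place of bromo on an aromatic carbon gives a 2.4-fold higher number from compound 1 to compound 3 (0.37 log units; beyond the scatter), a modest step that shows this read-out does respond to which group the ring carries. Nothing measured on these compounds accounts for either step.

The compounds shown leave open how far the number would move with an amine or a carboxylic acid on this ring. They also leave open whether chloro or trifluoromethyl would stand level with bromo or with methoxy.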